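Notes on moving a methyl group on the benzyl side

The source may hold more compounds than are shown below. What is called first, only, known or untested is meant among the compounds shown, and "the series" means these compounds.

Measured so far in a physicochemical assay for lipophilicity, at pH 7.4; on this read-out lower numbers stand for lower lipophilicity and higher numbers for higher lipophilicity:
- compound 1 `CNC(=O)c1cc(C(=O)NCCCC2CNCCO2)cn(Cc2ccccc2)c1=O` gives 1.4
- compound 2 `CCNC(=O)c1cc(C(=O)NC)c(=O)n(Cc2ccccc2)c1` gives 3
- compound 3 `CNC(=O)c1cc(C(=O)NC2CC2)cn([C@H](C)c2ccccc2)c1=O` gives 3.4

Compound 3 stands highest of the three in this assay, with compound 2 and compound 1 both lower beyond the scatter. Compound 4 `CNC(=O)c1cc(C(=O)NC2CC2)cn(Cc2cccc(C)c2)c1=O` has the same atoms, joined differently: 3-methylbenzyl in place of 1-phenylethyl on an aromatic nitrogen with 3-methylbenzyl in place of 1-phenylethyl on an aromatic nitrogen. Going by the values given here, the only measured step, a number 1.60 log units higher from compound 1 to compound 2 (beyond the scatter), is large but changes a saturated chain, so it does not bear on this change. Among the compounds with values here, no step measured at the aromatic nitrogen exists, and no step beyond the scatter is expected in this assay in either direction. The expected step, no change at the digits printed from compound 3 to compound 4 (within the scatter), is an estimate only. Compound 4 is estimated at 3.4 within 3 to 3.8 as the expected range.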

Compound 4, distribution coefficient: 3.6
Compound 4: the middle estimate sits 0.20 log units below what was measured, within the range that was stated.
By their numbers in this assay, from the lowest: compound 1; then compound 2; then compounds 3 and 4 (each within the scatter of the next).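

At the aromatic nitrogen, 3-methylbenzyl in place of 1-phenylethyl gives in this assay a number 0.20 log units higher from compound 3 to compound 4 (within the scatter), so the two isomeric groups cannot be told apart here, even though only 1-phenylethyl has a defined stereocentre. Going by these compounds alone, this is the first step read at this position, since the earlier step lay on a saturated chain. Nothing measured accounts for this result. Still open, going by these compounds, is whether an amine, a carboxylic acid or a longer chain in place of 3-methylbenzyl at this nitrogen would give a step beyond the scatter.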